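Phenyl to Thiophen-2-yl: Expected Effect on Antiproliferative Potency

The source may hold more compounds than are shown below. What is called first, only, known or untested is meant among the compounds shown, and "the series" means these compounds.

Compound 1 `COc1cc(C(=O)c2sc(-c3ccc(Cl)cc3)cc2N)cc(OC)c1OC`: 90 nM
Compound 2 `COc1cc(C(=O)c2sc(-c3ccccc3)cc2N)cc(OC)c1OC`: 13 nM
Compound 3 `COc1cc(C(=O)c2sc(-c3cc(OC)c(OC)c(OC)c3)cc2N)cc(OC)c1OC`: 3500 nM

Three compounds sharing one core were tested in a functional assay on FM3A cells (Mus musculus) for antiproliferative activity; on this read-out lower numbers stand for stronger inhibition and higher numbers for weaker inhibition. Compound 2 has the lowest number of the three. Among the compounds with values here, the only single-point step measured, a 6.9-fold lower number from compound 1 to compound 2 (0.84 log units; beyond the scatter), was modest but beyond the scatter, while compound 3 gives 3500 nM, far higher than compound 2.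

Compound 4 `COc1cc(C(=O)c2sc(-c3cccs3)cc2N)cc(OC)c1OC` differs from compound 2 by thiophen-2-yl in place of phenyl on an aromatic carbon. Within the data shown here, no measured step replaces the phenyl ring itself; the step of a 6.9-fold lower number from compound 1 to compound 2 (0.84 log units; beyond the scatter) only removed a chloro from that ring, and compound 3 shows that three methoxy groups on it raise the number greatly. Exchanging the ring is therefore expected to give at most a small step, probably upward. Compound 4 is estimated at 20 nM, range 6 nM to 70 nM, corresponding to an expected 1.5-fold higher number from compound 2 to compound 4 (0.19 log units; within the scatter).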

Compound 4, half-maximal inhibitory concentration: 1.7 nM
For compound 4 the middle estimate is 12-fold (1.07 log units) above the measured one, outside the stated range (below it).
By their numbers in this assay, from the lowest: compound 4; then compound 2; then compound 1; then compound 3.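

In this assay the phenyl ring itself can be exchanged with a gain: thiophen-2-yl gives a 7.6-fold lower number from compound 2 to compound 4 (0.88 log units; beyond the scatter) and, set against 4-chlorophenyl, gives a 53-fold lower number from compound 1 to compound 4 (1.72 log units; beyond the scatter) on the same spot. The earlier compounds shown here showed only higher numbers once groups were added to the phenyl ring, whereas a different ring here reaches a lower number. Nothing measured here explains this gain. Still open, from the compounds shown here alone, is whether furan-2-yl or thiophen-3-yl would reach similar numbers, and whether a chloro group on the thiophen-2-yl ring would raise the number as it does on phenyl.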